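The source may report more compounds than this note shows. Statements on the series, on what has been measured and on what is new or still open speak of the compounds shown alone.

The compounds share one core, a fused two-ring system in which a saturated ring carbon carries a variable group. Compound 1 `Cc1nn(-c2ncnc3nc[nH]c23)c2c1C(c1ccc(OC(C)C)cc1)CC(=O)N2` carries a 4-isopropoxyphenyl there, and in a functional assay on HEK293 cells for agonist activity at G-protein coupled receptor 39 (Homo sapiens), read by scintillation proximity assay and inositol phosphate accumulation, with a stated time of 75 min (on this read-out lower numbers stand for an effect already at smaller amounts and higher numbers for an effect only at larger amounts of compound), compound 1 gives 2700 nM. Of the two numbers shown, that is the highest. Compound 2 `CCC(C(=O)NC1CC(=O)Nc2c1c(C)nn2-c1ncnc2nc[nH]c12)c1ccccc1`, which carries a different group at that carbon, gives 79 nM in this assay, a far lower number than compound 1 and one that lies beyond the usual scatter. Compound 3 `Cc1cc(C)nc(-n2nc(C)c3c2NC(=O)CC3c2ccc(F)cc2F)n1`, with a different group on the ring nitrogen, gives > 10000 nM in this assay. That value is a limit of the assay and not a number (the limit of > 10000 nM in this assay, at which 1 of the 3 values shown sits).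

Compound 4 `Cc1nn(-c2ncnc3nc[nH]c23)c2c1C(C(=O)N(C)c1nccs1)CC(=O)N2` has not yet been measured. It differs from compound 1 in one place: methyl(1,3-thiazol-2-yl)carbamoyl in place of 4-isopropoxyphenyl on a saturated ring carbon. Among the measured compounds shown here, no measured pair shows exactly this change, so the expectation rests on compound 2, whose value of 79 nM shows that a group other than an aromatic ring at this carbon can go with a much lower number than compound 1. The step of a 4.5-fold lower number from compound 1 to compound 4 (0.65 log units; beyond the scatter) is therefore expected to run toward a lower number, beyond the scatter. Compound 4 is estimated to give 600 nM, most likely between 120 nM and 3000 nM.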

Compound 4, half-maximal effective concentration: 3300 nM
Beside the measured number, compound 4's estimate is 5.5-fold (0.74 log units) below it; the measured number lies above the stated range.
By their numbers in this assay, from the lowest: compound 2; then compounds 1 and 4 (each within the scatter of the next). At a limit, above all of these: compound 3.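

In this assay, replacing 4-isopropoxyphenyl with methyl(1,3-thiazol-2-yl)carbamoyl on this saturated ring carbon gives a 1.2-fold higher number from compound 1 to compound 4 (0.09 log units; within the scatter), so the number does not separate these two groups. One group holds a six-membered aromatic ring of carbon only and the other a five-membered aromatic ring with 2 hetero atoms, which shows that leaving the 4-isopropoxyphenyl behind does not by itself bring the low number seen with compound 2, 79 nM. No measurement shown here explains why such different groups give values within the scatter of each other.

As far as these compounds go, it remains open which part of the new group matters for this result, the thiazole ring or the methyl on the amide nitrogen, and a plain dimethylcarbamoyl group at this carbon would help to separate the two. From the compounds shown here alone, it also remains open whether a small amine, a carboxylic acid or a longer carbon chain at this position would give a value nearer to that of compound 2 or to that of compound 1.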